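The source may hold more compounds than are shown below. What is called first, only, known or untested is meant among the compounds shown, and "the series" means these compounds.

Measured compounds:
- compound 1 `CCOC(=O)c1ccc(-c2nn(Cc3ccccc3F)c3ccccc23)cc1` — in a functional assay on cells (Platelet, Homo sapiens) for inhibition (a lower number here means a stronger inhibitor, a higher number a weaker inhibitor), compound 1 gives > 10000 nM, a limit of the assay.
- compound 2 `CCOC(=O)c1ccc(-c2nn(Cc3cccc(OC)c3)c3ccccc23)cc1` — in this assay compound 2 gives > 10000 nM, also a limit.

Among the compounds with values here, compound 2 stands at the limit of this assay; no number is known for it, only that its value lies beyond the range measured. Within the data shown here, the one step between measured compounds, a step that the two limits leave unreadable from compound 1 to compound 2, cannot be sized, since both ends sit at the limit; this is the content of the limit of > 10000 nM in this assay, at which 2 of the 2 values shown sit.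

Compound 3 `CCOC(=O)c1ccc(-c2nn(Cc3ccc(OC)cc3)c3ccccc23)cc1` is not yet measured. It differs from compound 2 by 4-methoxyphenyl in place of 3-methoxyphenyl on a saturated chain carbon bound to an aromatic nitrogen.

Among the measured compounds shown here, no measured step bears directly on moving the methoxy group from the 3- to the 4-position of the benzyl group. For the measured compounds named here, the only evidence is that both measured compounds sit at the limit, and the same core with a third benzyl substituent is expected to behave similarly. The step from compound 2 to compound 3 is therefore expected to be essentially none, a step that the limit leaves unreadable from compound 2 to compound 3. Compound 3 is expected to give about 15000 nM in this assay, most likely again reported as a limit, with a range from 4000 nM to 60000 nM.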

Compound 3, half-maximal inhibitory concentration: > 10000 nM
Compound 3: only a limit was reported; the forecaster's own chance of this, stated with the estimate: 80%; the middle value is on the limit's open side.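

In this assay compound 3 gives > 10000 nM, a limit of the assay, and the steps to compound 3 from compound 1 and compound 2 cannot be read: the limit of > 10000 nM in this assay, at which 3 of the 3 values shown sit.

The compounds shown leave open how far apart these three compounds lie in this assay, and which change to the shared core, if any, would give a readable value.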